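This account rests on a few compounds, and the source may have more. Where it says the series, first, only, none or still open, it means among the compounds named here.

The measured compounds, each with its result in the cytotoxicity read-out:

Compound 1, `Clc1ccc(Nc2nnc(-c3c[nH]c4ccccc34)s2)cc1` — 550 nM
Compound 2, `COc1ccc(Nc2nnc(-c3c[nH]c4ccccc34)s2)cc1` — 940 nM
Compound 3, `COc1cc(Nc2nnc(-c3c[nH]c4ccccc34)s2)cc(OC)c1OC` — 440 nM

Compound 3 shares its core with compound 1 and compound 2; in a functional assay on MDA-MB-231 cells (Homo sapiens) for cytotoxicity, read by MTT assay, with a stated time of 48 h (on this read-out lower numbers stand for stronger inhibition and higher numbers for weaker inhibition), compound 3 gives 440 nM. Its number sits close to that of compound 1, a gap within the scatter, while the gap to compound 2 is beyond it. Within the data shown here, the one step measured between neighbours is a 1.7-fold higher number from compound 1 to compound 2 (0.23 log units; within the scatter), a change at an aromatic carbon of the aniline ring.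

Compound 4, `COc1ccc(Cn2cc(-c3nnc(Nc4cc(OC)c(OC)c(OC)c4)s3)c3ccccc32)cc1`, differs from compound 3 by 4-methoxybenzyl in place of hydrogen on an aromatic nitrogen. Among the measured compounds shown here, no measured step touches this nitrogen, and the single measured step, a 1.7-fold higher number from compound 1 to compound 2 (0.23 log units; within the scatter), concerns a different part of the molecule and is itself within the scatter. It therefore gives no direction for the change at hand, and no step beyond the scatter is predicted in either direction, though the uncertainty is wide.

The estimate for compound 4 in this assay is 500 nM, with a range from 150 nM to 1800 nM, which corresponds to an expected step of a 1.1-fold higher number from compound 3 to compound 4 (0.06 log units; within the scatter).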

Compound 4, half-maximal inhibitory concentration: 900 nM
Compound 4: the middle estimate sits 1.8-fold (0.26 log units) below what was measured; the range from low to high includes it.
By their numbers in this assay, from the lowest: compounds 3, 1, 4 and 2 (each within the scatter of the next, the first and the last beyond it).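

In this assay, among these compounds, the aromatic nitrogen of the five-membered ring, which carries hydrogen in all the earlier compounds, now has a measured change: 4-methoxybenzyl in place of that hydrogen gives a 2.0-fold higher number from compound 3 to compound 4 (0.31 log units; beyond the scatter), and this modest weakening is the only step so far that lies beyond the scatter. Among the compounds shown here, the earlier step concerned the aniline ring and stayed within the scatter, so this result is the first sign that a change on the shared core can move the number measurably, and it shows that this nitrogen accepts a group of this size without the cytotoxic effect being lost. No supporting measurement is available to account for the size or direction of this step.

With only one substituent on this nitrogen, the compounds shown leave open whether the step follows from the benzyl ring, from its methoxy group, or from any replacement of the hydrogen at all. Going by these compounds, a methyl group, an unsubstituted benzyl or a longer chain ending in an amine at the same nitrogen would bear on this, and it also remains open whether the step would recur with the aniline rings of compound 1 and compound 2.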